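This account rests on a few compounds, and the source may have more. Where it says the series, first, only, none or still open, it means among the compounds named here.

Of the compounds shown here, three sharing one core have been measured in an ADME assay (liver) for metabolic stability, with Liver microsome (Rattus norvegicus) as the target, using microsomes and NADPH, with a stated time of 30 min; a lower number here means slower removal, a higher number faster removal of the compound. Compound 1 (`CC#C[C@H]1CN(S(=O)(=O)c2ccc(N)nc2)CCN1c1ccc([C@@](O)(CO)C(F)(F)F)cc1`) gives 53 mL.min-1.g-1. Compound 2 (`CC#C[C@H]1CN(S(=O)(=O)c2ccc(N)nc2)CCN1c1ccc(S(=O)(=O)Nc2ccccc2)cc1`) gives > 399 mL.min-1.g-1, which is a limit of the assay. Compound 3 (`CC#C[C@H]1CN(S(=O)(=O)c2ccc(N)nc2)CCN1c1ccc(S(C)(=N)=O)cc1`) gives < 14 mL.min-1.g-1, which is also a limit of the assay. Compound 3 has the lowest number of the three.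

Compound 4 (`CC#C[C@H]1CN(S(=O)(=O)c2ccc(N)nc2)CCN1c1ccc(C(=O)NC)cc1`) differs from compound 3 in one place: a group of 4 heavy atoms (2 carbon, 1 nitrogen, 1 oxygen; no ring) in place of a group of 4 heavy atoms (1 carbon, 1 nitrogen, 1 oxygen, 1 sulfur; no ring), on an aromatic carbon. Methylcarbamoyl enters there, para to a large group.

Within the data shown here, two measured steps bear on this place. The change an at least 3.7-fold lower number from compound 1 to compound 3 (0.57 log units; beyond the scatter) is at least modest, and the change an at least 28-fold lower number from compound 2 to compound 3 (1.45 log units; beyond the scatter) is large. Both show the number falling as a larger group gives way to the small group of compound 3. Among the measured compounds shown here, no measured step swaps one small group for another, so only a modest change is expected, and upward, as the limit of compound 3 leaves little visible room below it. For compound 4 the estimated step is an at least 1.7-fold higher number from compound 3 to compound 4 (0.25 log units; that floor lies within the scatter). For compound 4 the expected value is 25 mL.min-1.g-1, within an estimated range of 10 mL.min-1.g-1 to 65 mL.min-1.g-1.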

Compound 4, intrinsic clearance in microsomes: 41 mL.min-1.g-1
Estimate against measurement, compound 4: 1.6-fold (0.21 log units) below, and the stated range covers the measured number.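

In this assay, exchanging one small group for another on this aromatic carbon does matter: methylcarbamoyl gives an at least 2.9-fold higher number from compound 3 to compound 4 (0.46 log units; beyond the scatter), although the two groups have the same heavy-atom count. Methylcarbamoyl also stands clearly apart from phenylsulfamoyl, with an at least 9.7-fold lower number from compound 2 to compound 4 (0.98 log units; beyond the scatter), yet the step of a 1.3-fold lower number from compound 1 to compound 4 (0.11 log units; within the scatter) lies within the scatter, so group size alone does not order the compounds, as compound 3 and compound 4 show. The number for compound 3 is a limit, not a measured value: the limit of < 14 mL.min-1.g-1 in this assay, at which 1 of the 4 values shown sits.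

The compounds shown leave open where a carboxylic acid, a nitrile or an unsubstituted carboxamide would fall on this aromatic carbon. They also leave open whether a longer chain on the amide nitrogen would shift the number.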